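The source may report more compounds than this note shows. Statements on the series, on what has been measured and on what is new or still open speak of the compounds shown alone.

Compound 1, `N[C@]1(C(=O)O)[C@H]2[C@@H](C[C@H]1OCc1ccccc1)[C@]2(F)C(=O)O`, gives 7.14 nM in an assay on CHO cells for binding affinity to metabotropic glutamate receptor 2 (Rattus norvegicus); on this read-out lower numbers stand for stronger inhibition and higher numbers for weaker inhibition.
Compound 2, `N[C@]1(C(=O)O)[C@H]2[C@@H](C[C@H]1OCCCc1ccccc1)[C@]2(F)C(=O)O`, gives 9.83 nM in this assay.
Compound 3, `N[C@]1(C(=O)O)[C@H]2[C@@H](C[C@H]1OCc1ccccc1Cl)[C@]2(F)C(=O)O`, gives 4.99 nM in this assay.

Compound 3 shows the lowest of the three numbers in this assay, yet neither gap separates it from the others: a 1.4-fold lower number from compound 1 to compound 3 (0.16 log units; within the scatter) and a 2.0-fold lower number from compound 2 to compound 3 (0.29 log units; within the scatter). Compound 4, `N[C@]1(C(=O)O)[C@H]2[C@@H](C[C@H]1OCc1cccc(Cl)c1)[C@]2(F)C(=O)O`, keeps every atom of compound 3 and only rearranges them: 3-chlorophenyl in place of 2-chlorophenyl on a saturated chain carbon bound to an oxygen on a saturated carbon. Among the compounds with values here, no measured step moves a chloro from one ring position to another, so the expectation rests on neighbours. Placing the chloro on the ring at all gave a 1.4-fold lower number from compound 1 to compound 3 (0.16 log units; within the scatter), and a far larger reshaping of the group bound to oxygen gave a 1.4-fold higher number from compound 1 to compound 2 (0.14 log units; within the scatter); every change so far has stayed inside the scatter of this assay. Compound 4 is therefore expected to sit close to compound 3, with a step of a 1.3-fold higher number from compound 3 to compound 4 (0.11 log units; within the scatter) that is not expected to exceed the scatter. Compound 4 is estimated at 6.5 nM, in a range from 2.5 nM to 16 nM.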

Compound 4, inhibition constant: 3.28 nM
Compound 4: the middle estimate sits 2.0-fold (0.30 log units) above what was measured; the range from low to high includes it.
By their numbers in this assay, from the lowest: compounds 4, 3, 1 and 2 (each within the scatter of the next, the first and the last beyond it).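

Moving the chloro from 2-chlorophenyl to 3-chlorophenyl gives a 1.5-fold lower number from compound 3 to compound 4 (0.18 log units; within the scatter) in this assay, so these two ring placements cannot be told apart. Even so, this change brings the first steps at this position that clear the scatter, though both are modest: adding the chloro as 3-chlorophenyl gives a 2.2-fold lower number from compound 1 to compound 4 (0.34 log units; beyond the scatter), and 3-chlorophenyl in place of phenethyl gives a 3.0-fold lower number from compound 2 to compound 4 (0.48 log units; beyond the scatter). The same addition as 2-chlorophenyl stayed within the scatter, yet compound 3 and compound 4 themselves remain inseparable, so this is a small difference rather than a firm preference.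

From the compounds shown here alone, whether bromo or methoxy in place of the chloro would keep or lose this gain remains open. Nothing measured here bears on why the steps differ in size.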